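Halogen exchange on the styryl ring of a cinnamoyl series

The compounds below may be only part of what the source reports. "The series", "measured", "known", "first", "only" and "open" are said of these compounds alone.

Compound 1 `CCCOC1=C(CCC)C(=O)/C(=C(O)/C=C/c2ccccc2)C(=O)C1(CCC)CCC` — 1.9 uM
Compound 2 `COC1=C(CC=C(C)C)C(=O)/C(=C(O)/C=C/c2ccccc2)C(=O)C1(CC=C(C)C)CC=C(C)C` — 10.3 uM
Compound 3 `CCCC1=C(OC)C(CCC)(CCC)C(=O)/C(=C(O)\C=C\c2ccc(I)cc2)C1=O` — 1.4 uM

Of the compounds shown here, three have been measured in a functional assay on A549 cells (Homo sapiens) for antiproliferative activity, read by sulforhodamine B assay, with a stated time of 3 days; on this read-out lower numbers stand for an effect already at smaller amounts and higher numbers for an effect only at larger amounts of compound. Compound 3 `CCCC1=C(OC)C(CCC)(CCC)C(=O)/C(=C(O)\C=C\c2ccc(I)cc2)C1=O` gives the lowest of the three numbers, 1.4 uM. Its nearest neighbour is compound 1, whose value of 1.9 uM sits within the scatter of the read-out, so the two cannot be placed in order. Compound 2, with 10.3 uM, stands beyond the scatter from compound 3 and gives the clearly higher number of the set.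

Compound 4 `CCCC1=C(OC)C(CCC)(CCC)C(=O)/C(=C(O)\C=C\c2ccc(Br)cc2)C1=O` has not yet been tested. It differs from compound 3 in one place: bromo in place of iodo on an aromatic carbon. Cut one bond further out, the change reads 4-iodophenyl to 4-bromophenyl. Going by the values given here, no measured pair in this set shows such a halogen exchange, so the expectation rests on the structural change alone. The step from compound 3 to compound 4 is expected to be small, a 1.3-fold higher number from compound 3 to compound 4 (0.11 log units; within the scatter), with no direction beyond the scatter. Compound 4 is therefore estimated at 1.8 uM in this assay, within a range of 0.8 uM to 4 uM.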

Compound 4, concentration for half-maximal effect: 2 uM
The estimate for compound 4 lay 1.1-fold (0.05 log units) below the measured number; the range from low to high includes it.
By their numbers in this assay, from the lowest: compounds 3, 1 and 4 (each within the scatter of the next); then compound 2.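

In this assay the exchange of iodo for bromo on this aromatic carbon gives a 1.4-fold higher number from compound 3 to compound 4 (0.15 log units; within the scatter) and so leaves the two halogens indistinguishable at this position. Going by these compounds alone, compound 3 and compound 4 form the first pair in the set that differs in one place, giving a direct reading of this position that the earlier compounds, which differ in several places, could not provide. No measurement is available that would account for this result.

As far as these compounds go, whether a smaller halogen such as chloro or fluoro, or a different group such as an amine or a carboxylic acid, would stay within the same range at this position remains open. Also open, from the compounds shown here alone, is what a plain phenyl ring, without any halogen, would give on the core of compound 3.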